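Trading a phenyl for an ethynyl on a nucleoside core

The compounds below may be only part of what the source reports. "The series", "measured", "known", "first", "only" and "open" are said of these compounds alone.

Compound 1, `CSc1ncnc2c1c(-c1ccccc1)cn2[C@@H]1O[C@H](CO)[C@@H](O)[C@H]1O`, gives > 20000 nM in a functional assay on CEM-DNR-bulk cells (Homo sapiens), read by MTT assay, with a stated time of 72 h; a lower number here means a stronger inhibitor, a higher number a weaker inhibitor; this is a limit of the assay, not a number.
Compound 2, `COc1ncnc2c1c(-c1ccccc1)cn2[C@@H]1O[C@H](CO)[C@@H](O)[C@H]1O`, gives > 20000 nM in this assay; again a limit.
Compound 3, `CNc1ncnc2c1c(-c1cccs1)cn2[C@@H]1O[C@H](CO)[C@@H](O)[C@H]1O`, gives > 20000 nM in this assay; again a limit.

Compound 1 thus stands at the limit, and so do the other two measured compounds; all three sit at the limit of > 20000 nM in this assay, at which 3 of the 3 values shown sit. For the measured compounds named here, the one step measured between them, a step that the two limits leave unreadable from compound 1 to compound 2, cannot be sized, since both ends are limits. Compound 3 is not linked to compound 1 by a single change.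

Compound 4, `C#Cc1cn([C@@H]2O[C@H](CO)[C@@H](O)[C@H]2O)c2ncnc(SC)c12`, differs from compound 1 as follows: ethynyl in place of phenyl on an aromatic carbon. No measured step resembles this change, so nothing shown points to a gain or a loss in this assay. With every value at hand sitting at the limit, the plainest expectation is that compound 4 also falls at or beyond it. Compound 4 is therefore estimated at 25000 nM, within 8000 nM to 80000 nM, which would mean an expected step that the limit leaves unreadable from compound 1 to compound 4 that cannot be told apart from no change.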

Compound 4, half-maximal inhibitory concentration: 110 nM
Compound 4: middle estimate off by 230-fold (2.36 log units), on the high side; measured number outside the range, below it.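

The group on this aromatic carbon of the five-membered ring turns out to matter a great deal: in this assay, ethynyl in place of phenyl gives an at least 180-fold lower number from compound 1 to compound 4 (2.25 log units; beyond the scatter). From the compounds shown here alone, compound 1 gives > 20000 nM, which is a limit of the assay, so the full size of this step stays unknown. The earlier compounds could not show that this position can change the result, since none of them gave a readable number: the limit of > 20000 nM in this assay, at which 3 of the 4 values shown sit.

The compounds shown leave open whether a methyl, a nitrile or a longer alkynyl chain on this same carbon would also give a low number. They also leave open whether the gain with ethynyl would hold with methoxy in place of methylsulfanyl, the other change seen here.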